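A few compounds are considered here, and "the series" means these few. Any claim that something is new, unique, unknown or untested is made for them only; others in the source may bear on it.

Measured in a functional assay on LNCaP cells (Homo sapiens) for antiproliferative activity; on this read-out higher numbers stand for weaker inhibition and lower numbers for stronger inhibition:
- compound 1 `C=CC[C@@H]1C[C@@H](c2ccc(Cl)c(Cl)c2)[C@H](NC(=O)c2cc(-c3c(Cl)cnn3C)c(Cl)o2)CN1`: 160 nM
- compound 2 `COCC[C@@H]1C[C@@H](c2ccc(Cl)c(Cl)c2)[C@H](NC(=O)c2cc(-c3c(Cl)cnn3C)c(Cl)o2)CN1`: 250 nM

Only these two compounds have been measured so far, and compound 2 stands within the usual scatter of compound 1. Among the compounds with values here, the one measured step is a 1.6-fold higher number from compound 1 to compound 2 (0.19 log units; within the scatter). It places methoxymethyl where vinyl stood, on a saturated chain carbon bound to a saturated ring carbon, and the rest of the molecule stays the same.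

The next compound, compound 3 `Cn1ncc(Cl)c1-c1cc(C(=O)N[C@@H]2CN[C@H](CC(=O)NC3CCC3)C[C@H]2c2ccc(Cl)c(Cl)c2)oc1Cl`, changes that same place: cyclobutylcarbamoyl in place of methoxymethyl on a saturated chain carbon bound to a saturated ring carbon. Here cyclobutylcarbamoyl stands in place of methoxymethyl, so 2-methoxyethyl becomes (cyclobutylcarbamoyl)methyl. Within the data shown here, no measured compound carries this group, which brings a ring and a hydrogen-bond donor that neither measured compound has at this place. Among the measured compounds shown here, the only guide is therefore the measured change at this place, a 1.6-fold higher number from compound 1 to compound 2 (0.19 log units; within the scatter), and it gives no direction to carry forward. No shift beyond the scatter is expected, although the larger change calls for a wide range.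

The expected change is a 1.2-fold higher number from compound 2 to compound 3 (0.08 log units; within the scatter). For compound 3 the estimate in this assay is 300 nM, with an expected range from 90 nM to 1000 nM.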

Compound 3, half-maximal inhibitory concentration: 80 nM
Compound 3: the middle estimate sits 3.8-fold (0.57 log units) above what was measured; the whole stated range lies above it.
By their numbers in this assay, from the lowest: compounds 3, 1 and 2 (each within the scatter of the next, the first and the last beyond it).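

Within the data shown here, this place on the shared core takes a larger group than the earlier compounds carried without any loss: in this assay, putting cyclobutylcarbamoyl, with its four-membered carbon ring and hydrogen-bond donor, where methoxymethyl stood gives a 3.1-fold lower number from compound 2 to compound 3 (0.49 log units; beyond the scatter) and is the first step at this place to lie beyond the scatter. Set against vinyl, the same group gives a 2.0-fold lower number from compound 1 to compound 3 (0.30 log units; within the scatter) and so can be separated only from methoxymethyl, with no order between compound 1 and compound 3. No measurement of any property of these compounds is at hand to account for the step.

The compounds shown leave open whether the ring, the amide hydrogen or the carbonyl matters most, since all three enter together in compound 3. A methylcarbamoyl group would keep the amide hydrogen without the ring, a dimethylcarbamoyl group would remove that hydrogen, and a cyclobutylmethyl group would keep the ring without the amide, while a carboxylic acid or an amine at this place would test quite different chain ends.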